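The source may report more compounds than this note shows. Statements on the series, on what has been measured and on what is new or still open speak of the compounds shown alone.

Compound 1 `CCc1ccccc1N(CC(=O)NCc1ccccc1)S(=O)(=O)c1ccc(C)cc1` — 224 nM
Compound 2 `CCc1ccccc1N(CC(=O)NCc1cccc(OC(F)(F)F)c1)S(=O)(=O)c1ccc(C)cc1` — 427 nM
Compound 3 `CCc1ccccc1N(CC(=O)NCc1ccc(Cl)cc1)S(=O)(=O)c1ccc(C)cc1` — 11.5 nM

All three share one core and were measured in a functional assay on CHO-K1 cells for antagonist activity at prostaglandin E2 receptor EP1 subtype (Homo sapiens), read by FLIPR and calcium flux; on this read-out lower numbers stand for stronger inhibition and higher numbers for weaker inhibition. Compound 3 stands lowest of the three numbers, and both of its steps to the others lie beyond the scatter, so it is the most potent compound measured here: a 19-fold lower number from compound 1 to compound 3 (1.29 log units; beyond the scatter) and a 37-fold lower number from compound 2 to compound 3 (1.57 log units; beyond the scatter). The remaining pair moved little, a 1.9-fold higher number from compound 1 to compound 2 (0.28 log units; within the scatter).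

Compound 4 `CCc1ccccc1N(CC(=O)NCc1ccc(Br)cc1)S(=O)(=O)c1ccc(C)cc1` differs from compound 3 in one place: bromo in place of chloro on an aromatic carbon. Among the compounds with values here, the only measured step that touches this place is the one that introduced the chloro group, a 19-fold lower number from compound 1 to compound 3 (1.29 log units; beyond the scatter), which was large. Nothing measured here trades one halogen for another, so the direction of a chloro-to-bromo swap cannot be read from these compounds directly; what can be said is that the group remains a single halogen atom at the same place, with no change in ring count, donors, acceptors or charge. For compound 4 the expected step in this assay is therefore small, a 1.0-fold lower number from compound 3 to compound 4 (0.02 log units; within the scatter), with no move beyond the scatter anticipated. Compound 4 is estimated at 11 nM, in a range from 4 nM to 35 nM.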

Compound 4, inhibition constant: 22.9 nM
Estimate against measurement, compound 4: 2.1-fold (0.32 log units) below; the measured number falls inside the stated range.
By their numbers in this assay, from the lowest: compounds 3 and 4 (each within the scatter of the next); then compounds 1 and 2 (each within the scatter of the next).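

In this assay, the exchange of one halogen for the other gives (a 2.0-fold higher number from compound 3 to compound 4 (0.30 log units; within the scatter)), so chloro and bromo cannot be told apart at this place, para to a large group. The gain seen with chloro now appears with a second halogen, as bromo in place of hydrogen gives (a 9.8-fold lower number from compound 1 to compound 4 (0.99 log units; beyond the scatter)), and the 4-bromophenyl group in place of the 3-(trifluoromethoxy)phenyl group gives (a 19-fold lower number from compound 2 to compound 4 (1.27 log units; beyond the scatter)); among these compounds, the two with a single halogen at this place stand apart from compound 1 and compound 2, which have none. No measured evidence accounts for what either halogen does here.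

The compounds shown leave open whether a halogen is needed at all, or whether a methyl, a methoxy or a nitrile at the same place would give a similar number. They also leave open whether fluoro or iodo would join chloro and bromo, and whether either of those two halogens would keep its gain on another carbon of the same ring.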